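Acetyl in place of fluoro: from compound 2 to compound 3

The source may hold more compounds than are shown below. What is called first, only, known or untested is meant among the compounds shown, and "the series" means these compounds.

Measured so far:
compound 1, `N#Cc1cccc(C#Cc2cccc(C(N)=O)c2)n1`, giving in an assay on membranes from brain (strain Sprague-Dawley) for displacement of a labelled ligand from metabotropic glutamate receptor 5 (Rattus norvegicus), read by scintillation counting, with a stated time of 60 min (on this read-out higher numbers stand for weaker inhibition and lower numbers for stronger inhibition), a value of > 10000 nM, which is a limit of the assay rather than a number;
compound 2, `N#Cc1cc(F)cc(C#Cc2cccc(F)n2)c1`, giving in this assay a value of 41 nM.

Within the data shown here, compound 2 holds the only number reported in this assay. The other value shown is a limit, described by the limit of > 10000 nM in this assay, at which 1 of the 2 values shown sits, for compound 1. Compound 3, `CC(=O)c1cccc(C#Cc2cc(F)cc(C#N)c2)n1`, has not yet been measured. It differs from compound 2 in one place: acetyl in place of fluoro on an aromatic carbon. Among the measured compounds shown here, no step between measured compounds covers this change, so the measured pairs give no guide to its size or direction, and the expectation rests on compound 2 alone. The step expected in this assay is a 3.7-fold higher number from compound 2 to compound 3 (0.56 log units; beyond the scatter), a moderate move toward weaker inhibition. The estimate for compound 3 in this assay is 150 nM, with a range from 30 nM to 1500 nM.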

Compound 3, inhibition constant: 64 nM
Estimate against measurement, compound 3: 2.3-fold (0.37 log units) above; the range from low to high includes it.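

In this assay, acetyl in place of fluoro on this aromatic carbon, next to the ring nitrogen, gives a 1.6-fold higher number from compound 2 to compound 3 (0.19 log units; within the scatter) and so leaves the two groups indistinguishable on this read-out. Compound 2 alone could not show this: the position holds 3 heavy atoms with a carbonyl and 1 hydrogen-bond acceptor in place of a single fluorine, with no step beyond the scatter. The comparison thus marks this place in the shared core as one where a larger group, and not only a lone fluorine, goes with a value of the same order.

Going by these compounds, whether an amine, a carboxylic acid or a longer chain such as propanoyl would fare alike at this position remains open. Why fluoro and acetyl read alike also remains open, as nothing measured among these compounds bears on it.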